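This account rests on a few compounds, and the source may have more. Where it says the series, first, only, none or still open, it means among the compounds named here.

Measured so far in an ADME assay on THP-1 cells (Homo sapiens) for cytotoxicity; on this read-out higher numbers stand for lower toxicity in this test and lower numbers for higher toxicity in this test:
- compound 1 `O=C(Nc1ccc(Cl)cc1)c1c(NC(=O)C(F)(F)F)sc2c1CCCCC2`: > 50000 nM (a limit)
- compound 2 `O=C(Nc1ccc(C(F)(F)F)cc1)c1c(NC(=O)C(F)(F)F)sc2c1CCCCC2`: 17200 nM
- compound 3 `CC(C)(C)NC(=O)c1c(NC(=O)C(F)(F)F)sc2c1CCCCC2`: > 50000 nM (a limit)

Compound 3 gives > 50000 nM, which is a limit and not a number. It stands at the limit of > 50000 nM in this assay, at which 2 of the 3 values shown sit, so only compound 2 has an exact value.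

Compound 4 `O=C(Nc1ccccc1)c1c(NC(=O)C(F)(F)F)sc2c1CCCCC2` carries phenyl in place of tert-butyl on an amide-type nitrogen.

Within the data shown here, no measured step makes this exact change, but three come close. Putting tert-butyl in place of 4-(trifluoromethyl)phenyl gave an at least 2.9-fold higher number from compound 2 to compound 3 (0.46 log units; beyond the scatter). Putting tert-butyl in place of 4-chlorophenyl gave a step that the two limits leave unreadable from compound 1 to compound 3. Trifluoromethyl in place of chloro gave an at least 2.9-fold lower number from compound 1 to compound 2 (0.46 log units; beyond the scatter). An aromatic ring on that nitrogen therefore goes with a lower number in compound 2 but not in compound 1.

Compound 4 has neither of these ring substituents, so only a small fall in the number is expected in this assay, and the result may again be only a limit. The expected change is an at least 1.2-fold lower number from compound 3 to compound 4 (0.09 log units; that floor lies within the scatter). Compound 4 is estimated at 40000 nM, with an expected range of 17000 nM to 70000 nM.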

Compound 4, half-maximal cytotoxic concentration: > 50000 nM
Compound 4: no number, only a limit; the forecaster's own chance of this, stated with the estimate: 55%; middle value at least 1.2-fold (0.09 log units) away from the limit.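

In this assay, compound 4 shows that a plain phenyl on the amide-type nitrogen leaves the result at a limit: the limit of > 50000 nM in this assay, at which 3 of the 4 values shown sit.
Hydrogen in place of trifluoromethyl on an aromatic carbon gives an at least 2.9-fold higher number from compound 2 to compound 4 (0.46 log units; beyond the scatter), so among the compounds shown, an aromatic ring on that nitrogen does not by itself go with a lower number, and only the ring carrying trifluoromethyl does. The steps from compound 3 to compound 4 and from compound 1 to compound 4 cannot be read, since both ends of each are limits.

As far as these compounds go, with three of the four compounds at the limit, any order among compound 1, compound 3 and compound 4 remains unknown. From the compounds shown here alone, it also remains open whether another group on the aromatic carbon, such as a nitrile, a methoxy group or an amine, would lower the number as trifluoromethyl does.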